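Swapping a dimethylamino for a hydroxy on the hydrazone aryl

This account rests on a few compounds, and the source may have more. Where it says the series, first, only, none or still open, it means among the compounds named here.

The series shares one core and varies the aryl group attached to the carbon that carries a double bond to nitrogen. Compound 1 `COc1ccc(/C=N/NC(=O)Nc2ccc(Oc3ccnc4cc(OCCCN5CCCCC5)c(OC)cc34)c(F)c2)c(OC)c1` carries a 2,4-dimethoxyphenyl there, and in a functional assay on HT-29 cells (Homo sapiens) for cytotoxicity, read by MTT assay, with a stated time of 72 h (a lower number here means a stronger inhibitor, a higher number a weaker inhibitor), compound 1 gives 1600 nM. For the measured compounds named here, compound 2 `COc1cc2c(Oc3ccc(NC(=O)N/N=C/c4ccc(N(C)C)cc4)cc3F)ccnc2cc1OCCCN1CCCCC1` carries a 4-(dimethylamino)phenyl instead, and in this assay compound 2 gives 1000 nM, the lowest of the two numbers so far; the change a 1.6-fold lower number from compound 1 to compound 2 (0.20 log units; within the scatter) stays within the scatter, so the two compounds are not distinguished by it.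

Compound 3 `COc1cc2c(Oc3ccc(NC(=O)N/N=C/c4ccc(O)cc4)cc3F)ccnc2cc1OCCCN1CCCCC1` follows the same line of variation: hydroxy in place of dimethylamino on an aromatic carbon, on an aromatic carbon of a six-membered aromatic ring of carbon only, para to a large group. Going by the values given here, the only measured step that bears on this position, the change a 1.6-fold lower number from compound 1 to compound 2 (0.20 log units; within the scatter), was small, and nothing in the data shows that a swap at this aromatic carbon moves the number beyond the scatter. The estimate for compound 3 in this assay is therefore 1300 nM, within the range 450 nM to 3800 nM, with the expected step of a 1.3-fold higher number from compound 2 to compound 3 (0.11 log units; within the scatter) not beyond the scatter.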

Compound 3, half-maximal inhibitory concentration: 470 nM
Compound 3: the middle estimate sits 2.8-fold (0.44 log units) above what was measured; the range from low to high includes it.
By their numbers in this assay, from the lowest: compound 3; then compounds 2 and 1 (each within the scatter of the next).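

In this assay, for the compounds shown here, this aryl position now shows a step beyond the scatter for the first time: hydroxy in place of dimethylamino gives a 2.1-fold lower number from compound 2 to compound 3 (0.33 log units; beyond the scatter), whereas the earlier exchange of aryl groups did not distinguish compound 1 from compound 2. Measured against the 2,4-dimethoxyphenyl group, the 4-hydroxyphenyl group gives a 3.4-fold lower number from compound 1 to compound 3 (0.53 log units; beyond the scatter), so compound 3 stands apart from both other compounds with the lowest number of the three, and the position is seen to respond to the group placed on the aryl ring, though both steps are modest. Nothing measured here explains why the hydroxy compound differs from the other two.

Still open, going by these compounds, is whether the hydroxy group itself matters or whether other small groups on the same aromatic carbon, such as an amino group, a fluorine or a carboxylic acid, would give a similar number. Also open, on these data alone, is whether the step carries over to other cell lines, since this assay alone supplies all three numbers.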